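Thiol and pyridinone esters against matrix metalloproteinase-9

The compounds below may be only part of what the source reports. "The series", "measured", "known", "first", "only" and "open" are said of these compounds alone.

Among the measured compounds shown here, three esters have numbers so far. Compound 1 `O=C(OCc1ccccc1Br)c1cccc(=O)[nH]1` gives 59000 nM in an assay on isolated protein for inhibition of matrix metalloproteinase-9 (Homo sapiens); on this read-out lower numbers stand for stronger inhibition and higher numbers for weaker inhibition. Compound 3 `O=C(OC/C=C/c1ccccc1)c1cccc(=O)[nH]1` gives 73000 nM in this assay. For the measured compounds named here, compound 2 `O=C(OCc1cccc(-c2ccccc2)c1)c1cccc(S)n1` gives 50000 nM in this assay; the gaps from compound 2 to compound 1 and to compound 3 both lie within the usual scatter, so the three numbers cannot be told apart, and no single-point step between measured compounds is available.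

Compound 4 `O=C(OCc1cccc(C(F)(F)F)c1)c1cccc(S)n1` is unmeasured. Relative to compound 2 the change is trifluoromethyl in place of phenyl on an aromatic carbon, at the place stated there.

Going by the values given here, with no measured step to lean on and the three known values sitting close together, no step beyond the scatter is expected from compound 2 to compound 4 in this assay; the estimated step is a 1.2-fold higher number from compound 2 to compound 4 (0.08 log units; within the scatter). Compound 4 is therefore expected to give about 60000 nM in this assay, with a range from 25000 nM to 150000 nM.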

Compound 4, half-maximal inhibitory concentration: 126000 nM
Beside the measured number, compound 4's estimate is 2.1-fold (0.32 log units) below it; the measured number falls inside the stated range.
By their numbers in this assay, from the lowest: compounds 2, 1, 3 and 4 (each within the scatter of the next, the first and the last beyond it).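

Among the compounds shown here, this is the first step read at a single place: in this assay, trifluoromethyl in place of phenyl gives a 2.5-fold higher number from compound 2 to compound 4 (0.40 log units; beyond the scatter), a modest step. The position, on an aromatic carbon and meta to a large group, therefore does register the group it carries, and in this one pair the phenyl ring goes with the lower number. Nothing at hand accounts for the step.

Open, on these data alone, is whether the trend holds for other groups at this place, such as an amine, a carboxylic acid or a methoxy group, since one pair cannot separate ring from no ring or size from group identity. Also open, as far as these compounds go, is whether the same change gives a similar step on the core of compound 1.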